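The source may hold more compounds than are shown below. What is called first, only, known or untested is meant among the compounds shown, and "the series" means these compounds.

Compound 1, `CCCCCOc1ccc2oc(/C=C/[S+](C)[O-])cc(=O)c2c1`, is tested in a functional assay on A549 cells (Homo sapiens) for cytotoxicity, with a stated time of 48 h (on this read-out lower numbers stand for stronger inhibition and higher numbers for weaker inhibition), where compound 1 gives 1600 nM. Among the three compounds measured so far, compound 1 carries the highest number. Its nearest companion is compound 2, `CCCCOc1ccc2oc(/C=C/[S+](C)[O-])cc(=O)c2c1`, for which the read-out is 1400 nM; the step of a 1.1-fold lower number from compound 1 to compound 2 (0.06 log units; within the scatter) lies within the scatter. Compound 3, `CC(C)CCOc1ccc2oc(/C=C/[S+](C)[O-])cc(=O)c2c1`, gives 1000 nM, and the step of a 1.6-fold lower number from compound 1 to compound 3 (0.20 log units; within the scatter) also stays within the scatter, as does a 1.4-fold lower number from compound 2 to compound 3 (0.15 log units; within the scatter).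

Compound 4, `COc1ccc2oc(/C=C/[S+](C)[O-])cc(=O)c2c1`, differs from compound 1 by hydrogen in place of butyl on a saturated chain carbon bound to an oxygen on an aromatic ring; cut one bond further out, the change reads pentyl to methyl, or pentyloxy to methoxy. The measured steps are all small edits of the same chain: a 1.1-fold lower number from compound 1 to compound 2 (0.06 log units; within the scatter) swaps hydrogen for methyl, and a 1.6-fold lower number from compound 1 to compound 3 (0.20 log units; within the scatter) and a 1.4-fold lower number from compound 2 to compound 3 (0.15 log units; within the scatter) rearrange the branching, each without leaving the scatter. None of them removes a whole butyl, so the step to compound 4 reaches beyond what the measured steps cover. The small steps among compounds 1, 2 and 3 give no reason to expect a dramatic change, yet a truncation of this size could plausibly push the number higher and beyond the scatter. The estimate for compound 4 is therefore 2500 nM, with a range from 900 nM to 7000 nM. This corresponds to an expected step of a 1.6-fold higher number from compound 1 to compound 4 (0.19 log units; within the scatter).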

Compound 4, half-maximal inhibitory concentration: 1600 nM
Compound 4: the middle estimate sits 1.6-fold (0.19 log units) above what was measured; the measured number falls inside the stated range.
By their numbers in this assay, from the lowest: compounds 3, 2, 1 and 4 (each within the scatter of the next).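

In this assay, going by these compounds alone, cutting the chain on the oxygen all the way back from pentyloxy to methoxy leaves the read-out where it was (no change at the digits printed from compound 1 to compound 4 (within the scatter)), so removing a whole butyl has no more visible effect than the small edits among the earlier compounds. The same holds for the branched and shorter chains, with hydrogen in place of isobutyl (a 1.6-fold higher number from compound 3 to compound 4 (0.20 log units; within the scatter)) and hydrogen in place of propyl (a 1.1-fold higher number from compound 2 to compound 4 (0.06 log units; within the scatter)), so at this position methyl, butyl, pentyl and isopentyl cannot be told apart in this read-out, and neither chain length nor branching separates these four compounds. No measured evidence is available to explain why the read-out tolerates this change.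

On these data alone, whether this tolerance extends to a longer chain such as decyl, or to a chain carrying an amine or a carboxylic acid, remains open. The compounds shown also leave open what a free hydroxyl in place of the methoxy of compound 4 would do, and whether any change at this position can move the read-out beyond the scatter.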